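This account rests on a few compounds, and the source may have more. Where it says the series, first, only, none or still open, it means among the compounds named here.

Of the compounds shown here, two on the shared core have been measured so far in a functional assay (muscle tissue) with Cavia porcellus as the target; on this read-out lower numbers stand for an effect already at smaller amounts and higher numbers for an effect only at larger amounts of compound. Compound 1 `COC(=O)C1=C(C)N=C(C)/C(=C(\O)OC)C1c1ccc(Br)cc1` gives 540 nM, and compound 2 `COC(=O)C1=C(C)N=C(C)/C(=C(\O)OC)C1c1cc(C)ccc1C` gives 100 nM, the lower of the two numbers. Compound 3 `COC(=O)C1=C(C)N=C(C)/C(=C(\O)OC)C1c1ccc(Cl)cc1Cl` is the next to be read, with 2,4-dichlorophenyl in place of 2,5-dimethylphenyl on a saturated ring carbon, which is next to the ring atom that bears a methoxycarbonyl group: 2,4-dichlorophenyl in place of 2,5-dimethylphenyl on a saturated ring carbon.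

Going by the values given here, only one measured step bears on this place: a 5.4-fold lower number from compound 1 to compound 2 (0.73 log units; beyond the scatter). It is modest but beyond the scatter, and it also involves an exchange of the group on the saturated ring carbon. The entering group resembles both measured groups in part: like 4-bromophenyl it is halogenated, and like 2,5-dimethylphenyl it is disubstituted. A position between the two measured values, close to compound 2, therefore seems reasonable, but a single step gives only weak guidance.

The expected result in this assay is a 1.2-fold higher number from compound 2 to compound 3 (0.08 log units; within the scatter), which would be no step beyond the scatter, although a step of the measured size remains possible in either direction. For compound 3 the estimated value is 120 nM, with an expected range of 35 nM to 400 nM.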

Compound 3, half-maximal effective concentration: 640 nM
Compound 3: the middle estimate sits 5.3-fold (0.73 log units) below what was measured, outside the stated range (above it).
By their numbers in this assay, from the lowest: compound 2; then compounds 1 and 3 (each within the scatter of the next).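

In this assay a disubstituted phenyl on the saturated ring carbon does not by itself keep the lower number: 2,4-dichlorophenyl in place of 2,5-dimethylphenyl gives a 6.4-fold higher number from compound 2 to compound 3 (0.81 log units; beyond the scatter) and thereby reverses a gain of similar size seen earlier in the series. Against 4-bromophenyl, 2,4-dichlorophenyl gives a 1.2-fold higher number from compound 1 to compound 3 (0.07 log units; within the scatter) and so the two halogen-bearing phenyl groups stand together, while compound 2, with 2,5-dimethylphenyl, has the lowest number of the three, and neither compound 1 nor compound 3 goes against this grouping. No measurement at hand gives a reason for this difference.

The exchange between compound 2 and compound 3 alters both the kind of substituent and where the substituents stand on the phenyl, and the compounds shown cannot separate these two changes. From the compounds shown here alone, a 2,4-dimethylphenyl or a 2,5-dichlorophenyl group at this place would divide them, and it remains open where an unsubstituted phenyl or an aminophenyl group would fall relative to the methyl-bearing and halogen-bearing groups.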